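Cycloheptyl in place of 3,3,3-trifluoropropyl on the shared core

This account rests on a few compounds, and the source may have more. Where it says the series, first, only, none or still open, it means among the compounds named here.

Within the data shown here, in a functional assay on HT-29 cells (Homo sapiens) for inhibition, read by luminescence and CellTiter-Glo, with a stated time of 24 h (a lower number here means that less compound is needed, a higher number that more compound is needed for the effect), compound 1 (`CC(C)n1nc(C(=O)N[C@H]2COc3ccccc3N(C)C2=S)nc1Cc1ccccc1`), with isopropyl on an aromatic nitrogen, gives 360 nM and compound 2 (`CN1C(=S)[C@@H](NC(=O)c2nc(Cc3ccccc3)n(CCC(F)(F)F)n2)COc2ccccc21`), with 3,3,3-trifluoropropyl there, gives 1550 nM as the higher of the two numbers so far. Compound 3 (`CN1C(=S)[C@@H](NC(=O)c2nc(Cc3ccccc3)n(C3CCCCCC3)n2)COc2ccccc21`) carries cycloheptyl in place of that 3,3,3-trifluoropropyl (cycloheptyl in place of 3,3,3-trifluoropropyl on an aromatic nitrogen). Among the measured compounds shown here, one measured step bears on this change (a 4.3-fold higher number from compound 1 to compound 2 (0.63 log units; beyond the scatter)), and it lies beyond the scatter and is modest in size. For the measured compounds named here, it concerns the same aromatic nitrogen, but no measured compound has a ring there, so it serves only as a loose guide. Cycloheptyl, like the isopropyl of compound 1 (360 nM), holds carbon only, so a modest step to a lower number is expected in this assay rather than a further rise, though it may stay within the scatter. The expected change is a 2.2-fold lower number from compound 2 to compound 3 (0.35 log units; beyond the scatter) on this reading. For compound 3 the estimated value is 700 nM (expected range 180 nM to 2500 nM).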

Compound 3, half-maximal effective concentration: 5530 nM
Beside the measured number, compound 3's estimate is 7.9-fold (0.90 log units) below it; the measured number lies above the stated range.
By their numbers in this assay, from the lowest: compound 1; then compound 2; then compound 3.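

In this assay the move to cycloheptyl gives a 3.6-fold higher number from compound 2 to compound 3 (0.55 log units; beyond the scatter) and so ends the reading that carbon-only groups on this aromatic nitrogen go with the lower number: carbon-only groups now stand at both ends of the series, with 3,3,3-trifluoropropyl in the middle. Against the isopropyl of compound 1, the same change gives a 15-fold higher number from compound 1 to compound 3 (1.19 log units; beyond the scatter) and is the largest step among these three compounds, showing that two groups of carbon alone can lie far apart at this position. Among these compounds, of the three groups, the only one with a ring, seven-membered and of carbon only, goes with the highest number, although a single ring cannot establish a trend for ring-bearing groups here.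

No measurement shown accounts for these differences. Going by these compounds, it remains open whether a smaller ring such as cyclopropyl or cyclopentyl, a ring holding oxygen such as tetrahydropyranyl, or a plain chain such as n-propyl would fall nearer to compound 1 or to compound 3 on the shared core.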